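Solubility series: phenoxy to isopentyl at the fused ring

A few compounds are considered here, and "the series" means these few. Any claim that something is new, unique, unknown or untested is made for them only; others in the source may bear on it.

Measured so far:
- compound 1, `COc1ccc(Oc2ccc3c(NCCCNCc4cc(F)ccc4OC)ccnc3c2)cc1`, 14500 nM
- compound 2, `c1ccc(Oc2ccc3c(NCCCNCc4ccco4)ccnc3c2)cc1`, 14500 nM
- compound 3, `COc1ccc(F)cc1CNCCCNc1ccnc2cc(C3CCCCC3)ccc12`, 4200 nM

In a physicochemical assay for solubility, with a stated time of 18 h, at pH 7.4 (a lower number here means a less soluble compound, a higher number a more soluble compound), compound 2 sits level with compound 1 at the digits shown, the two together the highest of the three numbers; compound 3 lies furthest from it, the gap being the only step beyond the scatter in this set. Among the compounds with values here, the one measured step that changes the same position is a 3.5-fold lower number from compound 1 to compound 3 (0.54 log units; beyond the scatter), where a ring-bearing ether substituent gives way to a saturated carbon group.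

Compound 4, `CC(C)CCc1ccc2c(NCCCNCc3ccco3)ccnc2c1`, is the not yet measured analogue of compound 2 with isopentyl in place of phenoxy on an aromatic carbon. Within the data shown here, the change runs in the same sense as the step from compound 1 to compound 3, a phenoxy group replaced by a substituent without oxygen, so a modest fall in this assay is expected rather than no change, though compound 3 is the only direct precedent. Compound 4 is therefore estimated at 5000 nM, with a range of 2500 nM to 10000 nM, which means an expected step of a 2.9-fold lower number from compound 2 to compound 4 (0.46 log units; beyond the scatter).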

Compound 4, solubility: 4200 nM
For compound 4 the middle estimate is 1.2-fold (0.08 log units) above the measured one, and the stated range covers the measured number.
By their numbers in this assay, from the lowest: compounds 3 and 4 (each within the scatter of the next); then compounds 1 and 2 (each within the scatter of the next).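

In this assay isopentyl in place of phenoxy gives a 3.5-fold lower number from compound 2 to compound 4 (0.54 log units; beyond the scatter) and so matches in size the earlier 3.5-fold lower number from compound 1 to compound 3 (0.54 log units; beyond the scatter) for cyclohexyl in place of 4-methoxyphenoxy. The fall at this position is thus seen on two different side chains rather than on that of compound 1 alone, and with an entering group that has no ring as well as with one that does. No supporting data bear on the cause of either step. 

Still open, as far as these compounds go, is whether a group such as a morpholine, a methoxyethoxy chain or a carboxylic acid at this aromatic carbon would hold the numbers of compound 1 and compound 2 or fall as these two pairs do. The shown pairs also leave open how a shorter chain such as ethyl would compare with isopentyl on the side chain of compound 2.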